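Tetrazolyl in place of ethoxycarbonyl on the anilide ring

This account rests on a few compounds, and the source may have more. Where it says the series, first, only, none or still open, it means among the compounds named here.

Within the data shown here, in an assay on isolated protein for inhibition of long-chain fatty acid transport protein 1 (Mus musculus) (on this read-out higher numbers stand for weaker inhibition and lower numbers for stronger inhibition), compound 2 `CCOC(=O)c1ccc(NC(=O)CSc2nnc(CNc3ccccc3)n2CC)cc1` gives 1100 nM, the only number in hand. Compound 1 `CCn1c(CNc2ccccc2)nnc1SCC(=O)Nc1ccc(Cl)cc1` returns only the assay limit > 10000 nM. Among the measured compounds shown here, the single measured step is an at least 9.0-fold lower number from compound 1 to compound 2 (0.95 log units; beyond the scatter), a change at the same aromatic carbon that compound 3 `CCn1nnc(-c2ccc(NC(=O)CSc3nnc(CNc4ccccc4)n3CC)cc2)n1` now alters again: 2-ethyl-2H-tetrazol-5-yl in place of ethoxycarbonyl on an aromatic carbon. That step shows what the ring tolerates when chloro gives way to ethoxycarbonyl, not when ethoxycarbonyl gives way to tetrazolyl, so for compound 3 no step beyond the scatter is expected, a 1.4-fold higher number from compound 2 to compound 3 (0.13 log units; within the scatter). Compound 3 is estimated at 1500 nM, range 500 nM to 5000 nM, in this assay.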

Compound 3, half-maximal inhibitory concentration: > 10000 nM
Compound 3: a limit, no number (the forecaster's own chance of this, stated with the estimate: 15%); middle value at least 6.6-fold (0.82 log units) away from the limit.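

Putting 2-ethyl-2H-tetrazol-5-yl in place of ethoxycarbonyl on this aromatic carbon gives an at least 9.0-fold higher number from compound 2 to compound 3 (0.95 log units; beyond the scatter) in this assay, so the tetrazolyl ring does not stand in for the ester here. Of the three groups tried at this place, only ethoxycarbonyl gives a number. The step from compound 1 to compound 3 cannot be read, and both values remain limits: the limit of > 10000 nM in this assay, at which 2 of the 3 values shown sit.

Going by these compounds, whether a carboxylic acid, a methyl ester or a longer alkyl ester at this place matches or passes compound 2 stays open.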